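From a phenyl amide to a 4-methylbenzyl amide

A few compounds are considered here, and "the series" means these few. Any claim that something is new, unique, unknown or untested is made for them only; others in the source may bear on it.

Measured so far:
Compound 1, `O=C(/C=C/c1coc2cc(O)ccc2c1=O)NCc1ccc(F)cc1`, gives in a functional assay (QGY7701 cells, Homo sapiens) for inhibition, read by MTT assay, with a stated time of 48 h (on this read-out lower numbers stand for stronger inhibition and higher numbers for weaker inhibition), only the assay limit > 100000 nM, not a number.
Compound 2, `COc1ccc2c(=O)c(/C=C/C(=O)Nc3ccccc3)coc2c1`, gives 14000 nM in this assay.
Compound 3, `O=C(/C=C/c1coc2cc(O)ccc2c1=O)NCc1ccccc1`, gives 63000 nM in this assay.

Among the measured compounds shown here, compound 2 holds the lowest of the two numbers known: the nearest, compound 3, sits at a higher number, and that gap lies beyond the usual scatter. The remaining value is a limit rather than a number (the limit of > 100000 nM in this assay, at which 1 of the 3 values shown sits). Compound 4, `COc1ccc2c(=O)c(/C=C/C(=O)NCc3ccc(C)cc3)coc2c1`, has not yet been measured. It differs from compound 2 in one place: 4-methylbenzyl in place of phenyl on an amide-type nitrogen. For the measured compounds named here, no measured step covers this exchange. Going by the values given here, the only measured step, an at least 1.5-fold lower number from compound 1 to compound 3 (0.20 log units; that floor lies within the scatter), swaps hydrogen for fluoro on a benzyl ring and stays within the scatter, so it says little here. Among the compounds with values here, compound 2 and compound 3 differ in two places, the group on the amide-type nitrogen and the core, so their values show only that compound 2 gives the lower number. On this thin ground compound 4 is expected to give a somewhat higher number than compound 2, the estimated step being a 2.1-fold higher number from compound 2 to compound 4 (0.33 log units; beyond the scatter). Compound 4 is therefore estimated at 30000 nM, within 8000 nM to 100000 nM.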

Compound 4, half-maximal inhibitory concentration: 10200 nM
Compound 4: the middle estimate sits 2.9-fold (0.47 log units) above what was measured; low and high end bracket the measured number.
By their numbers in this assay, from the lowest: compounds 4 and 2 (each within the scatter of the next); then compound 3. At a limit, above all of these: compound 1.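

On the core shared by compound 2 and compound 4, the amide-type nitrogen takes 4-methylbenzyl in place of phenyl without a readable change in this assay (a 1.4-fold lower number from compound 2 to compound 4 (0.14 log units; within the scatter)). Among the compounds shown here, this is the first measured step at this place on this core, and it shows that going from 6 to 8 heavy atoms, with the six-membered aromatic ring kept, leaves the number within the usual scatter. Nothing measured here gives a reason for this outcome.

The two compounds on this core cannot separate any contribution of the methyl from that of the extra carbon that links the ring to the nitrogen. From the compounds shown here alone, it also remains open how this nitrogen would respond to a group without an aromatic ring, such as an amine or a longer chain ending in a carboxylic acid.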